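Working notes: from compound 1 to compound 4

The source may hold more compounds than are shown below. What is called first, only, known or untested is meant among the compounds shown, and "the series" means these compounds.

Measured so far in a functional assay on HCC827 cells (Homo sapiens) for inhibition, read by MTT assay, with a stated time of 48 h, tested at 10 uM; a higher number here means more inhibition at the concentration tested (going by the name of the read-out), a lower number less inhibition:
- compound 1 `COc1cc(NC(=O)Nc2cc(Nc3ccc(OC)c(C)c3)ncn2)cc(OC)c1` gives 48.3%
- compound 2 `COc1cc(Br)ccc1Nc1cc(NC(=O)Nc2c(Cl)cccc2Cl)ncn1` gives 42.7%
- compound 3 `COc1cc(Nc2cc(NC(=O)Nc3c(Cl)cccc3Cl)ncn2)cc(OC)c1` gives 73.7%

Compound 1 stands second highest of the three numbers. Its nearest neighbour is compound 2, whose number lies within the usual scatter of that of compound 1, so no order between the two is claimed. Compound 3 is furthest, with a number beyond the scatter above that of compound 1. Going by the values given here, no two of the measured compounds differ in one place, so no single-point step is available in this assay to lean on.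

Compound 4 `COc1cc(NC(=O)Nc2cc(Nc3cc(C)cc(F)c3)ncn2)cc(OC)c1` has not yet been measured in this assay. It differs from compound 1 by 3-fluoro-5-methylphenyl in place of 4-methoxy-3-methylphenyl on a nitrogen on an aromatic ring. Among the compounds with values here, none of the measured compounds carries this change, so the expectation rests on compound 1 alone. The step is expected to be small, estimated as a number 3.3 percentage points lower from compound 1 to compound 4 (within the scatter), and not beyond the scatter in either direction. Compound 4 is therefore estimated at 45% in this assay, with a range from 25% to 65%.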

Compound 4, a percentage reported as inhibition, at one concentration (the size of the read-out at that concentration, not a potency): 62.1%
Beside the measured number, compound 4's estimate is 17.1 percentage points below it, and the stated range covers the measured number.
By their numbers in this assay, from the lowest: compounds 2 and 1 (each within the scatter of the next); then compound 4; then compound 3.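

In this assay, going by these compounds alone, this is the first single change that can be read: 3-fluoro-5-methylphenyl in place of 4-methoxy-3-methylphenyl on a nitrogen on an aromatic ring gives a number 13.8 percentage points higher from compound 1 to compound 4 (beyond the scatter). The value at this position therefore depends on the group it carries, with the rest of the structure held constant. The change swaps methoxy for fluorine and also alters the substitution pattern of the phenyl ring, and no available data explain the step.

Open, from the compounds shown here alone, is whether the fluorine, the loss of the methoxy group or the new arrangement of the groups on the ring accounts for the step, and whether it carries over to compounds that differ elsewhere. Also open, going by these compounds, is how this position responds to a phenyl ring bearing a carboxylic acid or an amine.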